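This account rests on a few compounds, and the source may have more. Where it says the series, first, only, none or still open, it means among the compounds named here.

- compound 1 `CC1(C)[C@H]2CC[C@]1(C)N(Cc1cn(-c3ccccc3F)nn1)C(=O)C2`: 40 nM
- compound 2 `Cc1ccc(-n2cc(CN3C(=O)C[C@@H]4CC[C@@]3(C)C4(C)C)nn2)cc1`: 50 nM
- compound 3 `CC1(C)[C@H]2CC[C@]1(C)N(Cc1cn(-c3cccc(O)c3)nn1)C(=O)C2`: not yet measured

In a functional assay on LoVo cells (Homo sapiens) for inhibition, read by MTT assay, with a stated time of 24 h (a higher number here means a weaker inhibitor, a lower number a stronger inhibitor), compound 1 gives 40 nM and compound 2 gives 50 nM, so compound 2 stands level with compound 1 within the scatter. Compound 3 carries 3-hydroxyphenyl in place of 4-methylphenyl on an aromatic nitrogen. For the measured compounds named here, the only measured step at this place, a 1.3-fold higher number from compound 1 to compound 2 (0.10 log units; within the scatter), is small, but neither compound in it carries a hydroxyl group, so it is a limited guide. The expected change, a 1.1-fold higher number from compound 2 to compound 3 (0.04 log units; within the scatter), is estimated to stay within the scatter. Compound 3 is expected at about 55 nM, with an estimated range of 18 nM to 170 nM.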

Compound 3, half-maximal inhibitory concentration: 410 nM
The estimate for compound 3 lay 7.5-fold (0.87 log units) below the measured number; the whole stated range lies below it.
By their numbers in this assay, from the lowest: compounds 1 and 2 (each within the scatter of the next); then compound 3.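

In this assay, the group on this aromatic nitrogen proves not to be freely exchangeable: 3-hydroxyphenyl in place of 4-methylphenyl gives an 8.2-fold higher number from compound 2 to compound 3 (0.91 log units; beyond the scatter), and in place of 2-fluorophenyl it gives a 10-fold higher number from compound 1 to compound 3 (1.01 log units; beyond the scatter). The earlier step stayed within the scatter, so only this result shows that the position can respond strongly to a change of group. Nothing available here explains the rise. Still open, as far as these compounds go, is whether the hydroxyl group itself or its place on the phenyl ring matters. A 4-hydroxyphenyl or 3-methoxyphenyl group would help separate these two possibilities.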